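The source may hold more compounds than are shown below. What is called first, only, known or untested is meant among the compounds shown, and "the series" means these compounds.

Measured in a functional assay on PC-3 cells (Homo sapiens) for cytotoxicity; a lower number here means that less compound is needed, a higher number that more compound is needed for the effect:
compound 1 `COC1=C(C)C(=O)/C(=C(O)/C=C/c2ccc(Br)cc2)C(=O)C1(C)C`: 17.7 ug/mL
compound 2 `COC1=C(C)C(=O)/C(=C(O)/C=C/c2cc(C)cc(C)c2)C(=O)C1(C)C`: 8.8 ug/mL
compound 3 `C=Cc1ccccc1/C=C/C(O)=C1/C(=O)C(C)=C(OC)C(C)(C)C1=O`: 4.6 ug/mL

Compound 3 stands within the scatter of compound 2, with a 1.9-fold lower number from compound 2 to compound 3 (0.28 log units; within the scatter), and clear of compound 1, with a 3.8-fold lower number from compound 1 to compound 3 (0.59 log units; beyond the scatter). Next is compound 4 `COC1=C(C)C(=O)/C(=C(O)/C=C/c2ccco2)C(=O)C1(C)C`, with furan-2-yl in place of 2-vinylphenyl on a double-bonded chain carbon bound to a double-bonded chain carbon. Those two steps bear on it, together with a 2.0-fold lower number from compound 1 to compound 2 (0.30 log units; within the scatter), but all three swap one phenyl group for another, so the guide is loose. Leaving 2-vinylphenyl has so far given nothing beyond the scatter on the lower side, so a modest move to a higher number in this assay is expected. The expected change is a 2.1-fold higher number from compound 3 to compound 4 (0.31 log units; beyond the scatter). The estimate for compound 4 is 9.5 ug/mL, within 4 ug/mL to 23 ug/mL.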

Compound 4, concentration for half-maximal effect: 20.6 ug/mL
Compound 4: middle estimate off by 2.2-fold (0.34 log units), on the low side, and the stated range covers the measured number.
By their numbers in this assay, from the lowest: compounds 3, 2, 1 and 4 (each within the scatter of the next, the first and the last beyond it).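

With furan-2-yl on a double-bonded chain carbon bound to a double-bonded chain carbon, this assay shows that a five-membered aromatic ring with a hetero atom does not match two of the phenyl-bearing compounds: a 4.5-fold higher number from compound 3 to compound 4 (0.65 log units; beyond the scatter) and a 2.3-fold higher number from compound 2 to compound 4 (0.37 log units; beyond the scatter). Against 4-bromophenyl, the same ring gives a 1.2-fold higher number from compound 1 to compound 4 (0.07 log units; within the scatter), so the phenyl groups do not all separate from furan-2-yl. No supporting data explain these steps. Still open, from the compounds shown here alone, is whether ring size or the ring oxygen matters here. A thiophen-2-yl or pyridin-3-yl group would help separate the two.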